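Shared-core series: a nitro analogue of compound 3

A few compounds are considered here, and "the series" means these few. Any claim that something is new, unique, unknown or untested is made for them only; others in the source may bear on it.

Values in a functional assay on HCT-116 cells (Homo sapiens) for inhibition, read by MTT assay, with a stated time of 48 h (on this read-out lower numbers stand for stronger inhibition and higher numbers for weaker inhibition), so far:
compound 1 `Brc1ccc(CSc2nnc(-c3ccncc3)n2-c2ccccc2)cc1`: 11100 nM
compound 2 `Fc1ccc(CSc2nnc(-c3ccncc3)n2-c2ccccc2)c(F)c1`: 11400 nM
compound 3 `c1ccc(CSc2nnc(-c3ccncc3)n2-c2ccccc2)cc1`: 16900 nM

Compound 3 has the highest of the three numbers in this assay, but the gaps are small: a 1.5-fold higher number from compound 1 to compound 3 (0.18 log units; within the scatter) and a 1.5-fold higher number from compound 2 to compound 3 (0.17 log units; within the scatter), both within the scatter, as is a 1.0-fold higher number from compound 1 to compound 2 (0.01 log units; within the scatter). On these numbers the three compounds cannot be told apart; no order is claimed.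

The next compound, compound 4 `O=[N+]([O-])c1cccc(CSc2nnc(-c3ccncc3)n2-c2ccccc2)c1`, differs from compound 3 in one place: nitro in place of hydrogen on an aromatic carbon. Within the data shown here, the only measured steps on that ring are the halogen changes above, and none of them moved the number beyond the scatter. Among the measured compounds shown here, no measured step introduces a nitro group, so there is nothing that bears on this change directly; the steps that do exist on the same ring suggest that substitution there has so far done little.

Compound 4 is therefore expected to land close to compound 3, with a step of a 1.2-fold lower number from compound 3 to compound 4 (0.08 log units; within the scatter) in this assay, not clearly beyond the scatter in either direction. The estimate for compound 4 is 14000 nM, with a range from 5000 nM to 40000 nM.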

Compound 4, half-maximal inhibitory concentration: 19800 nM
Beside the measured number, compound 4's estimate is 1.4-fold (0.15 log units) below it, and the stated range covers the measured number.
By their numbers in this assay, from the lowest: compounds 1, 2, 3 and 4 (each within the scatter of the next).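

Replacing hydrogen with nitro takes the substituents shown on this ring beyond halogens to a group of 3 heavy atoms with 2 hydrogen-bond acceptors, meta to a large group, yet in this assay the step stays within the scatter (a 1.2-fold higher number from compound 3 to compound 4 (0.07 log units; within the scatter)). The comparisons with the halogen-bearing rings, phenyl to 3-nitrophenyl aside, are also within the scatter (a 1.7-fold higher number from compound 2 to compound 4 (0.24 log units; within the scatter); a 1.8-fold higher number from compound 1 to compound 4 (0.25 log units; within the scatter)), so the four compounds cannot be told apart and this position has so far tolerated both halogens and nitro without a resolved change in this assay. No supporting measurement bears on this result.

Still open, as far as these compounds go, is whether an amine or a carboxylic acid on this ring, or a longer chain in place of the saturated carbon bound to the sulfur, would move the number beyond the scatter. From the compounds shown here alone, the phenyl on the triazole-free reading of the shared core and the remaining parts of that core are constant across these compounds, so their contribution in this assay remains unknown.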